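The source may hold more compounds than are shown below. What is called first, only, known or untested is meant among the compounds shown, and "the series" means these compounds.

Measured compounds: compound 1 `Nc1ccc(-c2cnc(C(=O)CCCCCCc3ccccc3)o2)cc1`, compound 2 `O=C(CCCCCCc1ccccc1)c1ncc(-c2ccc(O)cc2)o1`, compound 3 `NC(=O)c1cccc(-c2cnc(C(=O)CCCCCCc3ccccc3)o2)n1`.

In an assay (Rattus norvegicus) for inhibition of Fatty-acid amide hydrolase 1 (Homo sapiens) (a lower number here means a stronger inhibitor, a higher number a weaker inhibitor), compound 1 gives 90 nM, compound 2 gives 140 nM and compound 3 gives 1 nM. Compound 3 holds the lowest number of the three: the step of a 90-fold lower number from compound 1 to compound 3 (1.95 log units; beyond the scatter) and the step of a 140-fold lower number from compound 2 to compound 3 (2.15 log units; beyond the scatter) are both large and beyond the scatter, while the step of a 1.6-fold higher number from compound 1 to compound 2 (0.19 log units; within the scatter) lies within the scatter.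

Compound 4 `O=C(CCCCCCc1ccccc1)c1ncc(I)o1` is not yet measured. Its change from compound 3 is iodo in place of 6-carbamoylpyridin-2-yl on an aromatic carbon. For the measured compounds named here, no measured step removes this group outright, but the two steps that bear on it, a 90-fold lower number from compound 1 to compound 3 (1.95 log units; beyond the scatter) and a 140-fold lower number from compound 2 to compound 3 (2.15 log units; beyond the scatter), show that putting the 6-carbamoylpyridin-2-yl in place of a 4-aminophenyl or a 4-hydroxyphenyl lowers the number strongly. Taking it away again, and putting only an iodo with no ring, no hydrogen-bond donor and no hydrogen-bond acceptor in its place, is therefore expected to raise the number by a large step in this assay, plausibly past the numbers of compound 1 and compound 2, since those still carry an aromatic ring with a donor.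

The expected step is a 400-fold higher number from compound 3 to compound 4 (2.60 log units; beyond the scatter). Compound 4 is estimated at 400 nM, with a range from 80 nM to 2500 nM.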

Compound 4, inhibition constant: 3 nM
Estimate against measurement, compound 4: 130-fold (2.12 log units) above; the measured number lies below the stated range.
By their numbers in this assay, from the lowest: compound 3; then compound 4; then compounds 1 and 2 (each within the scatter of the next).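

At the aromatic carbon next to the ring oxygen, a lone iodo comes close to matching the 6-carbamoylpyridin-2-yl in this assay, with a 3.0-fold higher number from compound 3 to compound 4 (0.48 log units; beyond the scatter) being a modest step, though one beyond the scatter. The earlier compounds shown here tied the low number to the 6-carbamoylpyridin-2-yl, but compound 4 shows that a low number at this place needs neither a ring nor a hydrogen-bond donor or acceptor in the group that sits there. The same iodo also stands well ahead of both earlier phenyl groups, with a 47-fold lower number from compound 2 to compound 4 (1.67 log units; beyond the scatter) and a 30-fold lower number from compound 1 to compound 4 (1.48 log units; beyond the scatter) both large, so the 4-hydroxyphenyl and 4-aminophenyl can no longer be read as a baseline for this position, and the iodo-bearing compound 4 has a number much nearer that of compound 3 than those of compounds 1 and 2.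

Going by these compounds, whether this low number is particular to iodo or would also hold for a bromo, a chloro, a methyl or a bare hydrogen at the same carbon remains open. Nothing measured on these compounds says what lies behind the result.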